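The source may report more compounds than this note shows. Statements on the series, on what has been measured and on what is new or still open speak of the compounds shown alone.

Working notes on the series. Compound 1 `COc1ccc(CN(c2cc(OC)c(OC)c(OC)c2)S(=O)(=O)c2ccc(C)cc2)cc1`, compound 2 `COc1cc(N(Cc2nc3ccccc3[nH]2)S(=O)(=O)c2ccc(F)cc2)cc(OC)c1OC` and compound 3 `Cc1ccc(S(=O)(=O)N(Cc2nc3ccccc3[nH]2)c2ccc(Cl)cc2)cc1` have been run in a functional assay on PC-3 cells (Homo sapiens) for inhibition, read by MTT assay, with a stated time of 48 h; a higher number here means a weaker inhibitor, a lower number a stronger inhibitor. In this assay compound 1 gives 8220 nM, compound 2 gives 7990 nM and compound 3 gives 42200 nM. Compound 2 holds the lowest of the three numbers, but the value of compound 1 sits within the scatter of it, so no order between compound 1 and compound 2 can be read; compound 3 lies beyond the scatter, with a clearly higher number than compound 2.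

Compound 4 `COc1cc(N(Cc2nc3ccccc3[nH]2)C(=O)c2cccc(Cl)c2)cc(OC)c1OC` has not yet been measured. It differs from compound 2 in one place: (3-chlorophenyl)carbonyl in place of (4-fluorophenyl)sulfonyl on a nitrogen on an aromatic ring. For the measured compounds named here, no pair of measured compounds differs in exactly that way, so the size of this step has no direct precedent in the set. All three measured compounds carry a sulfonyl group on the nitrogen on an aromatic ring, and two of them, compound 1 and compound 2, sit close together, while compound 3 stands apart. With the rest of compound 2 kept unchanged, a modest step is expected, from compound 2 to compound 4 of a 1.5-fold higher number from compound 2 to compound 4 (0.18 log units; within the scatter) in this assay, possibly not beyond the scatter and, if anything, towards a weaker inhibitor. Compound 4 is therefore estimated at 12000 nM in this assay, with a range from 3000 nM to 50000 nM.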

Compound 4, half-maximal inhibitory concentration: > 50000 nM
Compound 4 was reported as a limit; the forecaster's own chance of this, stated with the estimate: 10%; at least 4.1-fold (0.61 log units) between middle value and limit.
By their numbers in this assay, from the lowest: compounds 2 and 1 (each within the scatter of the next); then compound 3. At a limit, above all of these: compound 4.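

For the compounds shown here, all three earlier compounds carry a sulfonyl group on the nitrogen on an aromatic ring, which left open whether anything else could stand in that place; compound 4 is the first test of that, and in this assay the change from (4-fluorophenyl)sulfonyl to (3-chlorophenyl)carbonyl, with the rest of compound 2 kept unchanged, gives an at least 6.2-fold higher number from compound 2 to compound 4 (0.79 log units; beyond the scatter). This place is therefore sensitive to what is attached there, although this rests on a single step and is no general rule for the series. The result for compound 4 is a limit of the assay and not a number: the limit of > 50000 nM in this assay, at which 1 of the 4 values shown sits.

The change replaces the sulfonyl with a carbonyl and alters the substituted phenyl ring in a single step, and the compounds shown cannot separate these two parts. From the compounds shown here alone, it remains open whether (4-fluorophenyl)carbonyl or (3-chlorophenyl)sulfonyl on this nitrogen would stay with compound 2 or fall with compound 4, and how a urea or a simple alkyl chain in the same place would read in this assay.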